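Adding a second chloro to an inactive aniline pair

The compounds below may be only part of what the source reports. "The series", "measured", "known", "first", "only" and "open" are said of these compounds alone.

Compound 1 `COc1cc(/C=C/C(=O)c2sc(Nc3ccc(Cl)cc3)nc2C)cc(OC)c1OC` in a functional assay on PC-3 cells (Homo sapiens) for cytotoxicity, read by MTT assay (on this read-out higher numbers stand for weaker inhibition and lower numbers for stronger inhibition), gives > 25000 nM, a limit of the assay.
Compound 2 `COc1cc(/C=C/C(=O)c2sc(Nc3cccc(Cl)c3)nc2C)cc(OC)c1OC` in this assay gives > 25000 nM, again a limit rather than a number.

Compound 2 therefore stands at the limit of > 25000 nM in this assay, at which 2 of the 2 values shown sit, and no measured potency is known for it. For the measured compounds named here, the only measured step, a step that the two limits leave unreadable from compound 1 to compound 2, is unreadable for the same reason, so the shared core with a single chloro on the aniline ring gives no readable signal either way. Compound 3 `COc1cc(/C=C/C(=O)c2sc(Nc3ccc(Cl)c(Cl)c3)nc2C)cc(OC)c1OC` carries the change (chloro in place of hydrogen on an aromatic carbon). Nothing measured bears on the size of this step; the two limits only show that both neighbours are weak. Compound 3 is expected to remain weak, with the estimated step that the limit leaves unreadable from compound 2 to compound 3 meaning little change. The estimate for compound 3 in this assay is 30000 nM, ranging from 8000 nM to 100000 nM.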

Compound 3, half-maximal inhibitory concentration: 19300 nM
Compound 3: the middle estimate sits 1.6-fold (0.19 log units) above what was measured; the range from low to high includes it.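

For the compounds shown here, the 3,4-dichlorophenyl group gives the first readable number: in this assay, compound 3 gives 19300 nM. Placing chloro on this aromatic carbon gives an at least 1.2-fold lower number from compound 2 to compound 3 (0.11 log units; that floor lies within the scatter), and the same comparison from the other single-chloro compound gives an at least 1.2-fold lower number from compound 1 to compound 3 (0.11 log units; that floor lies within the scatter). Each step is only a floor, so a second chloro on this ring could matter a good deal or hardly at all, and the true size of the step stays hidden: the limit of > 25000 nM in this assay, at which 2 of the 3 values shown sit.

From the compounds shown here alone, it remains open whether a readable number at this place depends on chloro itself or would also appear with another group, such as fluoro, methoxy, trifluoromethyl or an amine. Also open, going by these compounds, is how a carboxylic acid or a longer chain on this ring would read in this assay.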